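The source may hold more compounds than are shown below. What is called first, only, known or untested is meant among the compounds shown, and "the series" means these compounds.

Working notes on the purine-dione series

Compound 1, `CCCn1c(=O)n(CCC(N)=O)c(=O)c2[nH]cnc21`, carries a carbamoyl group two bonds along the chain from an aromatic nitrogen, and in a functional assay (trachea) with Cavia porcellus as the target (on this read-out lower numbers stand for an effect already at smaller amounts and higher numbers for an effect only at larger amounts of compound), compound 1 gives 13100 nM. Compound 2, `CCCn1c(=O)n(CCC#N)c(=O)c2[nH]cnc21`, differs from it by cyano in place of carbamoyl on a saturated chain carbon, two bonds along the chain from an aromatic nitrogen, and in this assay compound 2 gives 1700 nM. The step of a 7.7-fold lower number from compound 1 to compound 2 (0.89 log units; beyond the scatter) is modest but clear.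

Compound 3, `CCCn1c(=O)n(C)c(=O)c2c1ncn2CC(N)=O`, places its carbamoylmethyl group on the other core. The reading for compound 3 in this assay, > 100000 nM, is a limit of the assay and not a number; it sits at the limit of > 100000 nM in this assay, at which 1 of the 3 values shown sits. The difference between the core of compound 1 and the core of compound 3 is not broken down here.

Compound 4, `CCCn1c(=O)n(C)c(=O)c2c1ncn2CC#N`, has not yet been measured in this assay. It differs from compound 3 by cyano in place of carbamoyl on a saturated chain carbon bound to an aromatic nitrogen. This is the same kind of change as that from compound 1 to compound 2, not the same change: there the altered carbon lies two bonds along the chain from an aromatic nitrogen, here it is bound to an aromatic nitrogen.

Set beside a 7.7-fold lower number from compound 1 to compound 2 (0.89 log units; beyond the scatter), a step of an at least 1.2-fold lower number from compound 3 to compound 4 (0.09 log units; that floor lies within the scatter) is expected, tempered by the fact that the reading for compound 3 is only a limit. Compound 4 is therefore expected to come in around 80000 nM, with the likely span running from 15000 nM to 300000 nM.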

Compound 4, half-maximal effective concentration: 35300 nM
Estimate against measurement, compound 4: 2.3-fold (0.36 log units) above; the measured number falls inside the stated range.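

On the core of compound 3, the change again goes in the same direction as on the core of compound 1, with cyano in place of carbamoyl on a saturated chain carbon bound to an aromatic nitrogen giving an at least 2.8-fold lower number from compound 3 to compound 4 (0.45 log units; beyond the scatter) in this assay. Compound 3 reads > 100000 nM, which is a limit of the assay and not a number. The pair of steps therefore shows that the direction of the change holds on both cores in this series, but it does not show that the size carries over, and the change also sits at a different place on the chain in each case: the same change on two cores in this assay, a 7.7-fold lower number (0.89 log units; beyond the scatter) from compound 1 to compound 2 and an at least 2.8-fold lower number (0.45 log units; beyond the scatter) from compound 3 to compound 4; the limit leaves it open whether they differ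

Still open, as far as these compounds go, is whether a longer chain on the core of compound 3 would respond to the same change as these two chains do, and whether the direction would hold with a carboxylic acid or an amine at the end of the chain in place of carbamoyl. A firm comparison of size on the core of compound 3 would need a carbamoyl compound on that core whose reading is a number rather than a limit.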